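Phenyl for Propyl on the Amide Nitrogen

The source may hold more compounds than are shown below. What is called first, only, known or untested is meant among the compounds shown, and "the series" means these compounds.

Compound 2 `C=CC1=C(C(=O)NCCC)C(c2ccc(OC)c(OC)c2)OC1` is known in a functional assay on A549 cells (Homo sapiens) for cytotoxicity, read by MTT assay, with a stated time of 24 h (a lower number here means a stronger inhibitor, a higher number a weaker inhibitor), only by a limit: compound 2 gives > 100000 nM. Compound 1 `C=CC1=C(C(=O)Nc2ccccc2)C(c2ccc(OC)cc2)OC1` likewise shows only a limit in this assay, giving > 100000 nM. Taken together, this is the limit of > 100000 nM in this assay, at which 2 of the 2 values shown sit. Compound 3 `C=CC1=C(C(=O)Nc2ccccc2)C(c2ccc(OC)c(OC)c2)OC1` differs from compound 2 by phenyl in place of propyl on an amide-type nitrogen. Going by the values given here, both values measured so far are limits, so no measured step can be read between them, and the change in compound 3 is expected to bring no step beyond the scatter, meaning a number no higher from compound 2 to compound 3 (the limit leaves the size open) is estimated to be essentially none. Compound 3 is therefore expected to give 100000 nM, with a range from 30000 nM to 300000 nM.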

Compound 3, half-maximal inhibitory concentration: > 100000 nM
Compound 3 was reported as a limit; the forecaster's own chance of this, stated with the estimate: 85%; the middle value lies on the limit itself.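

Compound 3, like compound 1 and compound 2, is reported only as a limit, so no step between them can be read: the limit of > 100000 nM in this assay, at which 3 of the 3 values shown sit.

The compounds shown leave open whether phenyl or propyl on the amide-type nitrogen makes any difference in this assay.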